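The compounds below may be only part of what the source reports. "The series", "measured", "known", "first", "only" and "open" are said of these compounds alone.

Among the compounds with values here, compound 2 `Cc1cccc(NC(=O)Nc2cc(Oc3ccc4nc(NC(=O)C5CC5)sc4c3)ccc2F)c1` gives 580 nM in a functional assay on HT-29 cells (Homo sapiens) for inhibition, read by luminescence and CellTiter-Glo, with a stated time of 12 h (on this read-out lower numbers stand for an effect already at smaller amounts and higher numbers for an effect only at larger amounts of compound), the lowest of the two numbers measured so far; its nearest neighbour is compound 1 `O=C(CCc1cccc(C(F)(F)F)c1)Nc1cc(Oc2ccc3nc(NC(=O)C4CC4)sc3c2)ccc1F`, which in this assay gives 650 nM, and the step of a 1.1-fold lower number from compound 1 to compound 2 (0.05 log units; within the scatter) lies within the scatter. Compound 3 `O=C(Nc1nc2ccc(Oc3ccc(F)c(NCc4cccc(C(F)(F)F)c4)c3)cc2s1)C1CC1` has not yet been measured. It differs from compound 2 in that (3-(trifluoromethyl)benzyl in place of (3-methylphenyl)carbamoyl on a nitrogen on an aromatic ring). Within the data shown here, the only measured step, a 1.1-fold lower number from compound 1 to compound 2 (0.05 log units; within the scatter), exchanged the group on the carbonyl carbon while keeping the carbonyl in place, and the number hardly moved. The step to compound 3 goes further: the group that leaves carries the carbonyl together with one hydrogen-bond donor and one hydrogen-bond acceptor, and the group that enters carries none. Among the measured compounds shown here, no measured pair shows a change of this kind, so the expectation rests on thin ground. Compound 3 is nonetheless expected to give a higher number, by a 4.3-fold higher number from compound 2 to compound 3 (0.63 log units; beyond the scatter), though a step within the scatter cannot be excluded. The estimate for compound 3 in this assay is 2500 nM, with a range from 600 nM to 12000 nM.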

Compound 3, half-maximal effective concentration: > 20000 nM
Compound 3 gave a limit, no number (the forecaster's own chance of this, stated with the estimate: 10%); middle value at least 8.0-fold (0.90 log units) from the limit.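

At the place on a nitrogen on an aromatic ring, the change to 3-(trifluoromethyl)benzyl from (3-methylphenyl)carbamoyl is the first shown to move the read-out in this assay beyond the scatter, with an at least 34-fold higher number from compound 2 to compound 3 (1.53 log units; beyond the scatter). Where the carbonyl stayed on this nitrogen and only the group on it was exchanged, the result was a 1.1-fold lower number from compound 1 to compound 2 (0.05 log units; within the scatter), so the earlier compounds showed that two different groups could sit on that carbonyl, while this new step shows that the number does not hold once the carbonyl is gone along with the rest of the carbamoyl group. Compound 3 gives a limit of the assay and not a number, so the full size of the step remains unknown: the limit of > 20000 nM in this assay, at which 1 of the 3 values shown sits.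

The step changes the carbonyl, its hydrogen-bond donor and acceptor, and the trifluoromethyl group all at once, and the compounds shown do not separate these parts. As far as these compounds go, it stays open whether a 3-methylbenzyl group on this nitrogen would behave like 3-(trifluoromethyl)benzyl, and whether a sulfonamide could stand in for the carbonyl.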